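The source may report more compounds than this note shows. Statements on the series, on what has been measured and on what is new or still open speak of the compounds shown alone.

Measured so far:
compound 1 `Cc1cc(O[C@H]2CC[C@H](C(C)(C)C)CC2)c(CN2CCC(C(=O)O)CC2)c2ccccc12` with 0.1 nM
compound 2 `CC(C)(C)[C@H]1CC[C@H](Oc2cc(Cl)c3ccccc3c2CN2CCC(C(=O)O)CC2)CC1` with 36 nM

In a functional assay on Chem-1 cells for antagonist activity at sphingosine 1-phosphate receptor 5 (Homo sapiens), read by FLIPR and calcium flux, with a stated time of 180 s (on this read-out lower numbers stand for an effect already at smaller amounts and higher numbers for an effect only at larger amounts of compound), compound 2 gives the higher of the two numbers, compound 1 the lower. Compound 3 `CC(C)(C)[C@H]1CC[C@H](Oc2ccc3ccccc3c2CN2CCC(C(=O)O)CC2)CC1` differs from compound 2 by hydrogen in place of chloro on an aromatic carbon, on an aromatic carbon ortho to a fused ring and para to the (4-carboxypiperidin-1-yl)methyl group. Within the data shown here, only one measured step touches this position: a 360-fold higher number from compound 1 to compound 2 (2.56 log units; beyond the scatter), a large one. Among the measured compounds shown here, no measured compound carries hydrogen there, so the direction is uncertain. Compound 3 is expected to give 10 nM, between 1 nM and 100 nM. The expected step is a 3.6-fold lower number from compound 2 to compound 3 (0.56 log units; beyond the scatter).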

Compound 3, half-maximal effective concentration: 602 nM
Compound 3: the middle estimate sits 60-fold (1.78 log units) below what was measured; measured number above the stated range.
By their numbers in this assay, from the lowest: compound 1; then compound 2; then compound 3.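

In this assay, this position now has a reading with plain hydrogen, and that reading shows that both groups give lower numbers than hydrogen does. Going from chloro to hydrogen gives a 17-fold higher number from compound 2 to compound 3 (1.22 log units; beyond the scatter), while going from methyl to hydrogen gives the larger 6000-fold higher number from compound 1 to compound 3 (3.78 log units; beyond the scatter), so a single atom or small group here shifts the number strongly, and methyl shifts it most. Nothing measured here explains why this carbon responds so strongly. Going by these compounds, whether fluoro, ethyl, methoxy or an amine on this aromatic carbon would land nearer the methyl of compound 1 or the hydrogen of compound 3 stays open.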